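This account rests on a few compounds, and the source may have more. Where it says the series, first, only, none or still open, it means among the compounds named here.

Measured compounds:
- compound 1 `O=C(NCc1ccc(C(=O)N2CCCCc3ccccc32)c(F)c1)Nc1c(F)cccc1F`: 180 nM in a functional assay on HEK293 cells for agonist activity at Vasopressin V2 receptor (Homo sapiens), read by a luciferase reporter and cAMP accumulation; on this read-out lower numbers stand for an effect already at smaller amounts and higher numbers for an effect only at larger amounts of compound
- compound 2 `Cc1cc(C(=O)N2CCCCc3ccccc32)ccc1CNC(=O)NCC(=O)N1CCCC1`: 100 nM in this assay
- compound 3 `Cc1cc(C(=O)N2CCCCc3ccccc32)ccc1CNC(=O)NCC(=O)N1CCCCC1`: 150 nM in this assay

In this assay the number for compound 3 lies between those of the other two measured compounds, yet its gap to compound 1 and its gap to compound 2 both fall within the usual scatter, so the three measured compounds cannot be told apart on this read-out. Among the compounds with values here, the one measured step that changes the same part of the molecule is a 1.5-fold higher number from compound 2 to compound 3 (0.18 log units; within the scatter), where only the size of the ring on the carbonyl carbon changed.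

Compound 4 `CO[C@@H]1C[C@@H](C(=O)N(C)C)N(C(=O)NCc2ccc(C(=O)N3CCCCc4ccccc43)cc2C)C1` differs from compound 3 in that place: 2-(dimethylcarbamoyl)-4-methoxypyrrolidin-1-yl in place of (((piperidin-1-yl)carbonyl)methyl)amino on a carbonyl carbon. This change is larger than the measured step, as it replaces the amino-linked group with a ring attached directly to the carbonyl carbon, removes the hydrogen-bond donor and introduces two defined stereocentres. Within the data shown here, no measured pair covers such a change, so the direction cannot be read from the data. The estimate for compound 4 therefore stays close to compound 3, with a wide range, and is expected to be 150 nM (from 40 nM to 600 nM), a step of no change at the digits printed from compound 3 to compound 4 (within the scatter) that is expected to remain within the scatter.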

Compound 4, half-maximal effective concentration: 4.7 nM
Estimate against measurement, compound 4: 32-fold (1.50 log units) above; the whole stated range lies above it.
By their numbers in this assay, from the lowest: compound 4; then compounds 2, 3 and 1 (each within the scatter of the next).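

In this assay, this position on the carbonyl carbon can shift the number well beyond the scatter, which the change of ring size from compound 2 to compound 3 did not show. 2-(Dimethylcarbamoyl)-4-methoxypyrrolidin-1-yl gives a 32-fold lower number from compound 3 to compound 4 (1.50 log units; beyond the scatter) in place of the piperidine-bearing group, and a 21-fold lower number from compound 2 to compound 4 (1.33 log units; beyond the scatter) in place of the pyrrolidine-bearing one. This single change swaps the amino link for a ring on the carbonyl carbon, leaves no hydrogen-bond donor in the group and adds two defined stereocentres, and nothing available explains the lower number.

The compounds shown leave open which of these features matters, and whether the methoxy and dimethylcarbamoyl groups are both needed. A plain pyrrolidin-1-yl, a hydroxy in place of the methoxy, or a carboxylic acid in place of the dimethylcarbamoyl would each separate these contributions, as would the opposite stereoisomers.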